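The source may hold more compounds than are shown below. What is called first, only, known or untested is meant among the compounds shown, and "the series" means these compounds.

Measured compounds in an in vitro ADME assay on microsomes from liver (Homo sapiens) for metabolic stability; on this read-out higher numbers stand for fast clearance and lower numbers for slow clearance: compound 1 `COc1ccc(-c2cc(-c3ccc(S(=O)(=O)N(C)C)cc3)cnc2N)cn1` gives 98.8 mL.min-1.g-1; compound 2 `COc1ccc(-c2cc(-c3ccc(S(=O)(=O)NC4CC4)cc3)cnc2N)cn1` gives 15 mL.min-1.g-1; compound 3 `COc1ccc(-c2cc(-c3ccc(C(F)(F)F)cc3)cnc2N)cn1` gives 6.1 mL.min-1.g-1.

Compound 3 stands lowest of the three numbers in this assay, its nearest neighbour being compound 2 and the furthest compound 1. The step to compound 4 `COc1ccc(-c2cc(-c3ccc(C(N)=O)cc3)cnc2N)cn1` is carbamoyl in place of trifluoromethyl on an aromatic carbon. Among the compounds with values here, two measured steps bear on this position on the ring: a 16-fold lower number from compound 1 to compound 3 (1.21 log units; beyond the scatter) and a 2.5-fold lower number from compound 2 to compound 3 (0.39 log units; beyond the scatter), both of which end at the trifluoromethyl group of compound 3 and both of which went downward. Within the data shown here, no measured pair exchanges trifluoromethyl for carbamoyl, so the direction of this step cannot be read directly from the data; compound 3 already sits at the low end, and the two steps into it were far apart in size. Compound 4 is therefore expected to give a number close to that of compound 3, with the step of a 1.2-fold lower number from compound 3 to compound 4 (0.09 log units; within the scatter) estimated to fall within the scatter. Compound 4 is estimated at 5 mL.min-1.g-1 in this assay, within a range of 2 mL.min-1.g-1 to 14 mL.min-1.g-1.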

Compound 4, intrinsic clearance in microsomes: < 7 mL.min-1.g-1
Compound 4: a limit, no number; the forecaster's own chance of this, stated with the estimate: 15%; the middle value is on the limit's open side.
By their numbers in this assay, from the lowest: compound 3; then compound 2; then compound 1.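

In this assay the reading for compound 4 is a limit of the assay and not a number: the limit of < 7 mL.min-1.g-1 in this assay, at which 1 of the 4 values shown sits.

Compound 4 still lies clearly under both sulfamoyl compounds, with an at least 2.1-fold lower number from compound 2 to compound 4 (0.33 log units; beyond the scatter) and an at least 14-fold lower number from compound 1 to compound 4 (1.14 log units; beyond the scatter), so at this position low numbers are not confined to trifluoromethyl, which counts no hydrogen-bond donors or acceptors, and also occur with carbamoyl, which counts one of each. The step from compound 3 to compound 4 cannot be read, so no order between these two can be stated.

The compounds shown leave open whether low numbers hold once the amide hydrogens are replaced, as in dimethylcarbamoyl, which would set the dimethylamino group of compound 1 on a carbonyl instead of a sulfonyl sulfur. They also leave open how a carboxylic acid or a nitrile on this aromatic carbon would compare.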